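Swapping the oxolane attachment point in compound 2

The source may report more compounds than this note shows. Statements on the series, on what has been measured and on what is new or still open speak of the compounds shown alone.

Measured compounds:
compound 1, `COC(c1cc(Cl)c2c(c1Cl)C(=O)N(Cc1c(C)cc(C)[nH]c1=O)CC2)C1CCOCC1`, 3.4; 3.5 (2 entries)
compound 2, `Cc1cc(C)c(CN2CCc3c(Cl)cc([C@H](CO)[C@H]4CCOC4)c(Cl)c3C2=O)c(=O)[nH]1`, 2
compound 3, `Cc1cc(C)c(CN2CCc3c(Cl)cc(C(CO)C4CCOC4)c(Cl)c3C2=O)c(=O)[nH]1`, 2.1; 2.1 (2 entries)

The measurement here is a physicochemical assay for lipophilicity, at pH 7.4; a higher number here means a more lipophilic compound, a lower number a more polar compound. Compound 1 gives 3.4; 3.5 (2 entries), and its repeated entries agree closely, as the several entries of compound 1 in this assay, 3.4; 3.5 (2 entries) shows. Among the measured compounds shown here, compound 2 gives 2, the only number among its entries. Compound 3 gives 2.1; 2.1 (2 entries); compounds 2 and 3 differ only in whether the configuration is drawn, as the fact that one of compounds 2 and 3 is drawn with a defined configuration and the other without, at the place where they differ records, and their two values lie within the usual scatter of each other. The values of compound 1 sit higher than those of compound 2.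

The compound not yet measured is compound 4, `Cc1cc(C)c(CN2CCc3c(Cl)cc([C@H](CO)[C@H]4CCCO4)c(Cl)c3C2=O)c(=O)[nH]1`. It has the same atoms as compound 2, joined differently: oxolan-2-yl in place of oxolan-3-yl on a saturated chain carbon bound to an aromatic carbon and a saturated chain carbon. The number of ring atoms, donors and acceptors is unchanged.

For the measured compounds named here, with no measured step of this kind to lean on, the step from compound 2 to compound 4 in this assay is expected to be small, a number 0.10 log units higher from compound 2 to compound 4 (within the scatter), not beyond the scatter in either direction. Compound 4 is therefore estimated at 2.1, between 1.7 and 2.5.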

Compound 4, distribution coefficient: 2.1
For compound 4 middle estimate and measured number coincide at the digits printed; low and high end bracket the measured number.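

Replacing oxolan-3-yl with oxolan-2-yl on a saturated chain carbon bound to an aromatic carbon and a saturated chain carbon gives, in this assay, a number 0.10 log units higher from compound 2 to compound 4 (within the scatter). Among the compounds shown here, this is the first measured single change at this place, and for this one pair, which has the same atoms joined differently, moving the attachment point of the oxolane ring does not take the read-out beyond the scatter. Nothing measured here says why the two compounds read alike.

The compounds shown leave open how a different group at this place, such as an amine like piperidin-4-yl or a carboxylic acid, would read in this assay. They also leave open whether the opposite configuration at the oxolan-2-yl ring of compound 4 would give a similar number.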